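Enlarging the Amine: From Methylamino to Dipropylamino

A few compounds are considered here, and "the series" means these few. Any claim that something is new, unique, unknown or untested is made for them only; others in the source may bear on it.

compound 1 `CCN(CC)Cc1ccc(Cl)c(-c2ccccc2OC)c1` — 2000 nM
compound 2 `CNCc1ccc(Cl)c(-c2ccccc2OC)c1` — 1300 nM

Of the compounds shown here, two have been measured in an assay on isolated protein for binding affinity to 5-hydroxytryptamine receptor 6 (Homo sapiens); a higher number here means a weaker inhibitor, a lower number a stronger inhibitor. Compound 1 gives 2000 nM, and compound 2 gives 1300 nM. Going by the values given here, the only step between them, a 1.5-fold lower number from compound 1 to compound 2 (0.19 log units; within the scatter), is within the scatter, so the two cannot be ranked; compound 2 merely holds the lower of the two numbers. Compound 3 `CCCN(CCC)Cc1ccc(Cl)c(-c2ccccc2OC)c1` is not yet measured. It differs from compound 2 as follows: dipropylamino in place of methylamino on a saturated chain carbon bound to an aromatic carbon. Among the compounds with values here, the one measured step also exchanged an amine on the same carbon. It was a 1.5-fold lower number from compound 1 to compound 2 (0.19 log units; within the scatter), too small to show a direction. Compound 3 carries a larger amine than either measured compound, so the expected step is a 1.9-fold higher number from compound 2 to compound 3 (0.28 log units; within the scatter) in this assay, likely within or only slightly beyond the scatter. Compound 3 is therefore estimated at 2500 nM, with a range from 900 nM to 7000 nM.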

Compound 3, inhibition constant: > 10000 nM
Compound 3: a limit, no number (the forecaster's own chance of this, stated with the estimate: 5%); middle value at least 4.0-fold (0.60 log units) away from the limit.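

Compound 3 gives no number in this assay, only a limit of the assay: the limit of > 10000 nM in this assay, at which 1 of the 3 values shown sits.

Until now, the amine on this saturated chain carbon had shown no readable effect, as methylamino in compound 2 and diethylamino in compound 1 could not be told apart. Dipropylamino changes that, with an at least 7.6-fold higher number from compound 2 to compound 3 (0.88 log units; beyond the scatter) and an at least 5.0-fold higher number from compound 1 to compound 3 (0.69 log units; beyond the scatter), both beyond the scatter and both only minimum sizes. Among these three amines, then, only dipropylamino stands apart from the others, and affinity at this position does depend on which amine is attached.

As far as these compounds go, how far each step really reaches remains open. So does whether a cyclic amine such as pyrrolidine or piperidine, or a mixed amine such as N-methyl-N-propylamino, would behave like diethylamino or like dipropylamino at this carbon.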